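Cyclohexyl on the amide-type nitrogen: series notes

A few compounds are considered here, and "the series" means these few. Any claim that something is new, unique, unknown or untested is made for them only; others in the source may bear on it.

In a functional assay on MDA-MB-435 cells (Homo sapiens) for cytotoxicity, read by MTT assay, with a stated time of 72 h (on this read-out lower numbers stand for stronger inhibition and higher numbers for weaker inhibition), compound 1 `N[C@H]1CC[C@H](Nc2c(C(=O)NCc3ccc(F)cc3)nc(N3CCCCS3(=O)=O)c3cccnc23)CC1` gives 5000 nM, compound 2 `N[C@H]1CC[C@H](Nc2c(C(=O)NCc3ccc(Oc4ccccc4)cc3)nc(Br)c3cccnc23)CC1` gives 4000 nM and compound 3 `CN(C)c1ccc(CNC(=O)c2nc(Br)c3cccnc3c2N[C@H]2CC[C@H](N)CC2)cc1` gives 4000 nM. Compound 3 stands level with compound 2 and within the scatter of compound 1, so these numbers show no ranking. The next entry is compound 4 `N[C@H]1CC[C@H](Nc2c(C(=O)NC3CCCCC3)nc(Br)c3cccnc23)CC1`, which differs from compound 3 as follows: cyclohexyl in place of 4-(dimethylamino)benzyl on an amide-type nitrogen. Within the data shown here, one measured step bears on this change: no change at the digits printed from compound 2 to compound 3 (within the scatter), with dimethylamino in place of phenoxy on an aromatic carbon. That step keeps the six-membered aromatic ring of carbon only, whereas the change to compound 4 removes it, so the guidance is limited. Among the measured compounds shown here, no measured compound carries a non-aromatic ring on that amide-type nitrogen. The expected step is no change at the digits printed from compound 3 to compound 4 (within the scatter), with none expected beyond the scatter in this assay in either direction. The estimate for compound 4 is 4000 nM, with an expected range of 1500 nM to 10000 nM.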

Compound 4, half-maximal inhibitory concentration: > 10000 nM
Compound 4: a limit, no number; the forecaster's own chance of this, stated with the estimate: 10%; middle value at least 2.5-fold (0.39 log units) from the limit.
By their numbers in this assay, from the lowest: compounds 2, 3 and 1 (each within the scatter of the next). At a limit, above all of these: compound 4.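

In this assay, cyclohexyl in place of 4-(dimethylamino)benzyl on the amide-type nitrogen gives an at least 2.5-fold higher number from compound 3 to compound 4 (0.39 log units; beyond the scatter), the first step shown in this series that lies beyond the scatter. Compound 4 reads > 10000 nM, which is a limit and not a number: the limit of > 10000 nM in this assay, at which 1 of the 4 values shown sits. The earlier step changed only the group on the aromatic carbon and kept the six-membered aromatic ring of carbon only, whereas this one replaces that ring with a non-aromatic ring of carbon only, so this position is not indifferent to its substituent.

The change also removes the dimethylamino nitrogen and the benzyl carbon link, so the ring type is not separated from these. Plain benzyl or cyclohexylmethyl on the same nitrogen, with the rest of compound 3 kept, remains open.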